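The source may report more compounds than this note shows. Statements on the series, on what has been measured and on what is new or still open speak of the compounds shown alone.

The three measured compounds share one core and differ only in the aryl group on an amide-type nitrogen. Compound 1 `Cc1ccc(NC(=O)c2cccc(/C=C3\CC(=O)N(c4ccccc4)C3=O)c2)cc1` carries a 4-methylphenyl there. In an ADME assay on HCT-116 cells (Homo sapiens) for cytotoxicity, read by MTT assay, with a stated time of 72 h (a lower number here means a stronger inhibitor, a higher number a weaker inhibitor), compound 1 reaches only a limit of the assay, > 100000 nM. Compound 2 `COc1ccc(NC(=O)c2cccc(/C=C3\CC(=O)N(c4ccccc4)C3=O)c2)c(C)c1` likewise gives only a limit, > 100000 nM. The step that the two limits leave unreadable from compound 1 to compound 2 thus stays unreadable. Compound 3 `CSc1cccc(NC(=O)c2cccc(/C=C3\CC(=O)N(c4ccccc4)C3=O)c2)c1` gives 65200 nM, which is an at least 1.5-fold lower number from compound 1 to compound 3 (0.18 log units; that floor lies within the scatter) and an at least 1.5-fold lower number from compound 2 to compound 3 (0.18 log units; that floor lies within the scatter). Where compound 1 stands is told by the limit of > 100000 nM in this assay, at which 2 of the 3 values shown sit. Compound 4 `CCOc1ccc(NC(=O)c2cccc(/C=C3\CC(=O)N(c4ccccc4)C3=O)c2)cc1` differs from compound 1 by ethoxy in place of methyl on an aromatic carbon. For the measured compounds named here, no measured step replaces methyl by ethoxy at this place; the only readable steps, both to compound 3, show movement that may be no more than scatter, and compound 2 sits at the limit. The step from compound 1 to compound 4 is therefore expected to be a number no higher from compound 1 to compound 4 (the limit leaves the size open), with compound 4 expected to sit at the limit again or close to it. Compound 4 is estimated at 100000 nM, with a range from 40000 nM to 250000 nM.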

Compound 4, half-maximal inhibitory concentration: 84800 nM
For compound 4 the middle estimate is 1.2-fold (0.07 log units) above the measured one, within the range that was stated.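

For the compounds shown here, the series shows an at least 1.1-fold lower number from compound 1 to compound 4 (0.07 log units; that floor lies within the scatter) with ethoxy in place of methyl on an aromatic carbon para to a large group, the first readable value for a group at that place. In this assay the result also reads as an at least 1.1-fold lower number from compound 2 to compound 4 (0.07 log units; that floor lies within the scatter) and as a 1.3-fold higher number from compound 3 to compound 4 (0.11 log units; within the scatter) and thus sets 4-ethoxyphenyl level with 3-(methylsulfanyl)phenyl within the scatter. As far as these compounds go, compound 1 and compound 2 remain limits and not numbers, so the true size of their steps stays open: the limit of > 100000 nM in this assay, at which 2 of the 4 values shown sit.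

From the compounds shown here alone, whether a longer alkoxy chain, an amine or a carboxylic acid at this place would move the number beyond the scatter stays open. The rest of the shared core is the same in all compounds shown, so they say nothing about changes there.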